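The source may hold more compounds than are shown below. What is called first, only, known or untested is meant among the compounds shown, and "the series" means these compounds.

Measured compounds:
- compound 1, `O=C(OCc1ccc(Cl)c(Cl)c1)N(c1ccccc1)C1CN2CCC1CC2`: 60 nM
- compound 2, `O=C(OCCCc1ccc(F)c(F)c1)N(c1ccccc1)C1CN2CCC1CC2`: 100 nM
- compound 3, `COc1ccc(CCCOC(=O)N(c2ccccc2)C2CN3CCC2CC3)cc1F`: 260 nM

In an assay on CHO cells for displacement of a labelled ligand from muscarinic acetylcholine receptor M5 (Homo sapiens), read by scintillation counting, with a stated time of 2 h (a lower number here means a stronger inhibitor, a higher number a weaker inhibitor), compound 2 gives 100 nM, which places it second highest of the three numbers; compound 1 sits within the scatter of it, while compound 3 lies beyond the scatter on the weaker side. Compound 4, `O=C(OCCCc1ccccc1)N(c1ccccc1)C1CN2CCC1CC2`, has not yet been measured. It differs from compound 2 in one place: phenyl in place of 3,4-difluorophenyl on a saturated chain carbon, three bonds along the chain from an oxygen next to a carbonyl group.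

Within the data shown here, no measured step removes a halogen outright. Among the measured compounds shown here, the only step that touches the same ring is a 2.6-fold higher number from compound 2 to compound 3 (0.41 log units; beyond the scatter), where one fluoro was exchanged for methoxy and the number rose modestly. Compound 1 carries a dichlorinated ring on a shorter chain, and its value and that of compound 2 lie within the scatter of each other, so they show no direction. On that basis a modest weakening is expected for compound 4 rather than a large one, with a 2.0-fold higher number from compound 2 to compound 4 (0.30 log units; within the scatter) as the estimated step. Compound 4 is therefore expected to give about 200 nM in this assay, within a range of 80 nM to 500 nM.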

Compound 4, inhibition constant: 260 nM
Estimate against measurement, compound 4: 1.3-fold (0.11 log units) below; the range from low to high includes it.
By their numbers in this assay, from the lowest: compounds 1 and 2 (each within the scatter of the next); then compounds 3 and 4 (each within the scatter of the next).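

In this assay, the bare phenyl of compound 4 shows that the two fluoro groups of the 3,4-difluorophenyl ring count at this position, with a 2.6-fold higher number from compound 2 to compound 4 (0.41 log units; beyond the scatter). Set against the 3-fluoro-4-methoxyphenyl ring, phenyl shows no change at the digits printed from compound 3 to compound 4 (within the scatter), so on this chain these two rings are not told apart, and only the 3,4-difluorophenyl ring stands clear of bare phenyl. The wider gap, a 4.3-fold higher number from compound 1 to compound 4 (0.64 log units; beyond the scatter), comes with phenethyl in place of 3,4-dichlorophenyl, so it changes chain and ring together and cannot be given to either alone.

Nothing available bears on why these steps take the sizes they do. The compounds shown leave open whether a 4-fluorophenyl or 3,4-dichlorophenyl group on the chain of compound 2 would match the 3,4-difluorophenyl ring, and how an amine on that ring would read.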